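Chloro to methyl swap: two compounds measured, one awaited

This account rests on a few compounds, and the source may have more. Where it says the series, first, only, none or still open, it means among the compounds named here.

Compound 1 `N#Cc1c(-c2ccco2)[n+]([O-])c2ccc(Cl)cc2[n+]1[O-]` and compound 2 `Cc1ccc2c(c1)[n+]([O-])c(C#N)c(-c1ccco1)[n+]2[O-]` share one core and differ at a single point. In a physicochemical assay for lipophilicity, measured as octanol-water partition (a lower number here means a more polar compound, a higher number a more lipophilic compound), compound 1 gives 1.11, and compound 2 gives 0.845. The change between them is methyl in place of chloro on an aromatic carbon and it made a step of a number 0.27 log units lower from compound 1 to compound 2 (within the scatter). Compound 3 `COc1ccc(-c2c(C#N)[n+]([O-])c3cc(Cl)ccc3[n+]2[O-])cc1` carries a different group on its core; how its core differs from the core of compound 1 is not broken down here. In this assay compound 3 gives 2.09, the highest of the three numbers, lying beyond the scatter from both compound 1 and compound 2.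

Compound 4 `COc1ccc(-c2c(C#N)[n+]([O-])c3cc(C)ccc3[n+]2[O-])cc1` has not yet been measured in this assay. It differs from compound 3 by methyl in place of chloro on an aromatic carbon, the same change as from compound 1 to compound 2, at the same place. For the measured compounds named here, the only guide is the single earlier step of a number 0.27 log units lower from compound 1 to compound 2 (within the scatter), which was small. Nothing among these compounds shows whether that step carries over unchanged to the core of compound 3, so the expectation rests on one pair alone. On that basis the step from compound 3 to compound 4 is expected to be a number 0.27 log units lower from compound 3 to compound 4 (within the scatter). In this assay compound 4 is therefore estimated at 1.82. For compound 4 the lower end is expected at 1.5 and the upper end at 2.15.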

Compound 4, partition coefficient: 1.83
Estimate against measurement, compound 4: 0.01 log units below; the measured number falls inside the stated range.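

In this assay methyl in place of chloro on an aromatic carbon gives a number 0.26 log units lower from compound 3 to compound 4 (within the scatter) and, on the other core, a number 0.27 log units lower from compound 1 to compound 2 (within the scatter) so on both cores the step is within the scatter, and the change carries over from the core of compound 1 to the core of compound 3 without a step beyond the scatter appearing. This does not show that methyl and chloro are distinguishable at this place in this read-out, since neither step clears the scatter, and two pairs on two cores make no rule for any further core in the series. No measurement shown bears on why the step has the size it has.

The compounds shown leave open what other groups would do on this aromatic carbon, for example an amine, a carboxylic acid or a longer chain such as butyl, on either the core of compound 1 or the core of compound 3. They also leave open whether the same change would stay within the scatter on cores other than these two, such as one carrying a pyridine or a morpholine in place of the group that separates compound 1 from compound 3.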